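The source may report more compounds than this note shows. Statements on the series, on what has been measured and on what is new or still open speak of the compounds shown alone.

In an assay on cells for inhibition of ileal sodium/bile acid cotransporter (Homo sapiens) (a higher number here means a weaker inhibitor, a lower number a stronger inhibitor), compound 1, `CCCC[C@]1(CC)CS(=O)(=O)c2ccc(NC(=O)OCc3ccccc3)cc2[C@@H](c2ccccc2)[C@H]1O`, gives 400 nM. Compound 2, `CCCCCCNc1ccc2c(c1)[C@@H](c1ccccc1)[C@@H](O)[C@](CC)(CCCC)CS2(=O)=O`, differs from it only at the nitrogen on the aromatic ring, where hexyl stands in place of benzyloxycarbonyl; in this assay compound 2 gives 1670 nM, and the step of a 4.2-fold higher number from compound 1 to compound 2 (0.62 log units; beyond the scatter). Going by the values given here, of the two numbers measured so far, compound 2 therefore carries the higher one. Compound 3, `CCCC[C@]1(CC)CS(=O)(=O)c2ccc(NC(C)=O)cc2[C@@H](c2ccccc2)[C@H]1O`, keeps everything of compound 2 except one change: acetyl in place of hexyl on a nitrogen on an aromatic ring. A single measured step bears on this, the one in which a hexyl replaced a carbonyl-bearing group on that nitrogen and the number rose; the new change runs the other way, from the hexyl back to a group with a carbonyl, although acetyl is not benzyloxycarbonyl. A modest move toward lower numbers is therefore expected, a 2.6-fold lower number from compound 2 to compound 3 (0.41 log units; beyond the scatter). Compound 3 is estimated at 650 nM, with a likely range from 250 nM to 1700 nM.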

Compound 3, half-maximal inhibitory concentration: 90 nM
For compound 3 the middle estimate is 7.2-fold (0.86 log units) above the measured one; measured number below the stated range.
By their numbers in this assay, from the lowest: compound 3; then compound 1; then compound 2.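

At the nitrogen on the aromatic ring, the choice of group matters more than the first pair suggested: in this assay, acetyl in place of hexyl gives a large step (a 19-fold lower number from compound 2 to compound 3 (1.27 log units; beyond the scatter)). A carbonyl on that nitrogen does not settle the number by itself, since methyl in place of benzyloxy on the carbonyl carbon also gives a step beyond the scatter (a 4.4-fold lower number from compound 1 to compound 3 (0.65 log units; beyond the scatter)), leaving compound 3 with the lowest number of the three. Nothing available explains why these groups differ.

Hexyl to acetyl changes both the chain and the carbonyl, so the compounds shown do not separate the two. An ethyl group or a free amine on that nitrogen would help separate them, and a longer acyl chain such as hexanoyl would show how far the carbonyl group can be extended.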